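Aryl urea in place of propyl urea on a shared core

The compounds below may be only part of what the source reports. "The series", "measured", "known", "first", "only" and "open" are said of these compounds alone.

Measured so far:
compound 1 `C=CS(=O)(=O)N1CCN(c2ncnc3sc(-c4cccc5ccccc45)cc23)CC1` — 23700 nM
compound 2 `CCCNC(=O)N1CCN(c2ncnc3sc(-c4ccc(N5CCN(C)CC5)cc4)cc23)CC1` — 8330 nM

Of the compounds shown here, two have been tested in a functional assay on MDA-MB-231 cells (Homo sapiens) for antiproliferative activity, read by MTT assay, with a stated time of 48 h; on this read-out lower numbers stand for stronger inhibition and higher numbers for weaker inhibition. Compound 1 `C=CS(=O)(=O)N1CCN(c2ncnc3sc(-c4cccc5ccccc45)cc23)CC1` gives 23700 nM. Compound 2 `CCCNC(=O)N1CCN(c2ncnc3sc(-c4ccc(N5CCN(C)CC5)cc4)cc23)CC1` gives 8330 nM, the lower of the two numbers, and the gap to compound 1 lies beyond the usual scatter. The two differ in more than one place, so nothing about any single change can be read from this pair.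

Compound 3 `CN1CCN(c2ccc(-c3cc4c(N5CCN(C(=O)Nc6ccc(Cl)c(C(F)(F)F)c6)CC5)ncnc4s3)cc2)CC1` has not been measured in this assay. Relative to compound 2 the change is 4-chloro-3-(trifluoromethyl)phenyl in place of propyl on an amide-type nitrogen. Both compounds keep the same urea carbonyl and the same remainder of the structure.

For the measured compounds named here, no measured pair in this set isolates the effect of exchanging a propyl for an aryl group on the urea nitrogen, so the expectation rests on compound 2 alone. Compound 3 is expected to give a lower number than compound 2, with an estimated step of a 2.8-fold lower number from compound 2 to compound 3 (0.44 log units; beyond the scatter). The estimate for compound 3 in this assay is 3000 nM, within a range from 800 nM to 12000 nM.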

Compound 3, half-maximal inhibitory concentration: 2220 nM
The estimate for compound 3 lay 1.4-fold (0.13 log units) above the measured number; measured number inside the range.
By their numbers in this assay, from the lowest: compound 3; then compound 2; then compound 1.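

In this assay, the exchange of propyl for 4-chloro-3-(trifluoromethyl)phenyl on the amide-type nitrogen gives a 3.8-fold lower number from compound 2 to compound 3 (0.57 log units; beyond the scatter), a modest step. For the compounds shown here, this is the first pair here that differs in only one place, so it gives the first direct reading of this position: with the rest of the structure held constant, the larger group, with 11 heavy atoms in place of 3, is compatible with antiproliferative activity and gives the lower number. The change brings in an aromatic ring, chlorine and fluorine together, without adding any hydrogen-bond donor or acceptor to the substituent, and no available evidence bears on why the number moves.

The compounds shown leave open which part of the new group accounts for the step, since the ring and its two substituents enter together; a plain phenyl, or a phenyl carrying only chlorine or only trifluoromethyl, on the same nitrogen would begin to separate them. They also leave open whether size alone could produce a similar step, as a longer alkyl chain such as hexyl in place of propyl would test.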